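A few compounds are considered here, and "the series" means these few. Any claim that something is new, unique, unknown or untested is made for them only; others in the source may bear on it.

Measured in a functional assay on RAW264.7 cells (Mus musculus) for inhibition, read by Griess assay, with a stated time of 24 h (a lower number here means a stronger inhibitor, a higher number a weaker inhibitor), so far, compound 1 `O=C(S[C@]12CCC[C@H]1C(=O)NC2=O)c1ccc(F)cc1` gives 390000 nM as the higher number, and compound 2 `CC(=O)OC1CC[C@]2(SC(=O)c3ccc(F)cc3)C(=O)NC(=O)[C@H]12` gives 34300 nM as the lower of the two. Compound 3 `O=C(SC1CC[C@]2(SC(=O)c3ccc(F)cc3)C(=O)NC(=O)[C@H]12)c1ccc(F)cc1` has not been measured yet. The structural change from compound 2 to compound 3 is ((4-fluorophenyl)carbonyl)sulfanyl in place of acetoxy on a saturated ring carbon and amounts to ((4-fluorophenyl)carbonyl)sulfanyl in place of acetoxy on a saturated ring carbon. For the measured compounds named here, one measured step bears on this, an 11-fold lower number from compound 1 to compound 2 (1.06 log units; beyond the scatter) as a large change when acetoxy took the place of hydrogen on a saturated ring carbon. Going by the values given here, no measured compound yet carries the entering group at this carbon, so the direction remains uncertain. A moderate further move towards a lower number is expected, smaller than that earlier step. For compound 3 the estimate is 15000 nM with 4000 nM to 60000 nM as the expected range. That estimate means a 2.3-fold lower number from compound 2 to compound 3 (0.36 log units; beyond the scatter) as the expected step.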

Compound 3, half-maximal inhibitory concentration: 98300 nM
For compound 3 the middle estimate is 6.6-fold (0.82 log units) below the measured one, outside the stated range (above it).
By their numbers in this assay, from the lowest: compound 2; then compound 3; then compound 1.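

In this assay, putting ((4-fluorophenyl)carbonyl)sulfanyl in place of acetoxy on this saturated ring carbon gives a 2.9-fold higher number from compound 2 to compound 3 (0.46 log units; beyond the scatter) and so gives back part of the gain seen with acetoxy, even though the entering group has 10 heavy atoms against 4. Compared with hydrogen at the same carbon, the entering group still gives a 4.0-fold lower number from compound 1 to compound 3 (0.60 log units; beyond the scatter) and so, among these three compounds, both groups at this carbon give a lower number than hydrogen, with acetoxy giving the lowest. Nothing measured here explains the difference between the two groups.

Going by these compounds, it remains open whether a small group such as a hydroxyl or an amine at this carbon would give a lower number than acetoxy. A 4-fluorobenzoyloxy group would show whether the sulfur or the fluorophenyl ring accounts for the loss.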